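Working notes: from allyl to benzyl on the nitrogen

The source may hold more compounds than are shown below. What is called first, only, known or untested is meant among the compounds shown, and "the series" means these compounds.

Measured so far in a functional assay on MCF7 cells (Homo sapiens) for cytotoxicity, read by MTT assay, with a stated time of 48 h; a lower number here means a stronger inhibitor of growth, a higher number a weaker inhibitor of growth
compound 1 `CCn1c(C(F)(F)F)nc2cc(Cl)c(Cl)cc21` gives 72900 nM
compound 2 `CC(C)n1c(C(F)(F)F)nc2cc(Cl)c(Cl)cc21` gives 70500 nM
compound 3 `C=CCn1c(C(F)(F)F)nc2cc(Cl)c(Cl)cc21` gives 87000 nM

Compound 3 cannot be separated from the other two compounds. The measured steps are a 1.2-fold higher number from compound 1 to compound 3 (0.08 log units; within the scatter) and a 1.2-fold higher number from compound 2 to compound 3 (0.09 log units; within the scatter), and the remaining one is a 1.0-fold lower number from compound 1 to compound 2 (0.01 log units; within the scatter). So far, changing this group has not moved the number beyond the scatter.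

Next is compound 4 `FC(F)(F)c1nc2cc(Cl)c(Cl)cc2n1Cc1ccccc1`, not yet measured. The change from compound 3 is phenyl in place of vinyl on a saturated chain carbon bound to an aromatic nitrogen. In words, this is phenyl in place of vinyl on a saturated chain carbon bound to an aromatic nitrogen, or allyl to benzyl.

Going by the values given here, the closest precedent is the step at the same carbon, a 1.2-fold higher number from compound 1 to compound 3 (0.08 log units; within the scatter). Among the compounds with values here, no measured compound carries phenyl at this place, so the precedent is only partial. No step beyond the scatter is expected in this assay. The estimated step is a 1.5-fold lower number from compound 3 to compound 4 (0.16 log units; within the scatter). Compound 4 is expected at 60000 nM. The estimated range for compound 4 runs from 25000 nM to 120000 nM.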

Compound 4, concentration for 50% growth inhibition: 8700 nM
The estimate for compound 4 lay 6.9-fold (0.84 log units) above the measured number, and the stated range ends above it.
By their numbers in this assay, from the lowest: compound 4; then compounds 2, 1 and 3 (each within the scatter of the next).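

In this assay the group on the aromatic nitrogen does affect the number, with benzyl standing apart from all three earlier groups: a 10-fold lower number from compound 3 to compound 4 (1.00 log units; beyond the scatter), an 8.1-fold lower number from compound 2 to compound 4 (0.91 log units; beyond the scatter) and an 8.4-fold lower number from compound 1 to compound 4 (0.92 log units; beyond the scatter). Going by these compounds alone, compounds 1, 2 and 3 had stayed within the scatter of one another, so phenyl on the saturated chain carbon is the first change here to move the number beyond it, though this rests on compound 4 alone. No accompanying evidence bears on why this change has such an effect.

The compounds shown do not separate the aromatic ring from the mere presence of a larger group, which a cyclohexylmethyl group on the same nitrogen would test. Also open, on these data alone, is how a longer chain between nitrogen and phenyl, or a methoxy or amine on the phenyl, would behave.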